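Aroyl-urea variation on the shared core: nitrophenyl entry

This account rests on a few compounds, and the source may have more. Where it says the series, first, only, none or still open, it means among the compounds named here.

Working notes. In a functional assay on HeLa cells (Homo sapiens) for inhibition, read by MTT assay, with a stated time of 72 h (on this read-out lower numbers stand for stronger inhibition and higher numbers for weaker inhibition), compound 1 `CN(C(=O)NC(=O)c1ccc(Cl)cc1Cl)c1nc(C(F)(F)F)c(C(=O)N/N=C/c2ccccc2C(F)(F)F)s1` gives 9 ug/mL, compound 2 `CN(C(=O)NC(=O)c1c(Cl)cccc1Cl)c1nc(C(F)(F)F)c(C(=O)N/N=C/c2ccccc2C(F)(F)F)s1` gives 5.23 ug/mL, and compound 3 `CN(C(=O)NC(=O)c1ccccc1F)c1nc(C(F)(F)F)c(C(=O)N/N=C/c2ccccc2C(F)(F)F)s1` gives 10.1 ug/mL. All three differ only in the aryl group on the carbonyl carbon, and every step among them stays within the scatter: a 1.7-fold lower number from compound 1 to compound 2 (0.24 log units; within the scatter), a 1.1-fold higher number from compound 1 to compound 3 (0.05 log units; within the scatter), a 1.9-fold higher number from compound 2 to compound 3 (0.29 log units; within the scatter). Compound 3 is therefore not separated from either neighbour in this assay.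

Compound 4 `CN(C(=O)NC(=O)c1cccc([N+](=O)[O-])c1)c1nc(C(F)(F)F)c(C(=O)N/N=C/c2ccccc2C(F)(F)F)s1` continues the same variation: 3-nitrophenyl in place of 2-fluorophenyl on a carbonyl carbon. The three measured steps all bear on this change and none of them left the scatter, so for compound 4 a step of a 1.0-fold lower number from compound 3 to compound 4 (0.00 log units; within the scatter) is expected, that is, none beyond the scatter. The estimate for compound 4 in this assay is 10 ug/mL, with a range from 4 ug/mL to 25 ug/mL.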

Compound 4, half-maximal inhibitory concentration: 4.15 ug/mL
Compound 4: the middle estimate sits 2.4-fold (0.38 log units) above what was measured, and the stated range covers the measured number.
By their numbers in this assay, from the lowest: compounds 4, 2, 1 and 3 (each within the scatter of the next, the first and the last beyond it).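

In this assay this position gives its first steps beyond the scatter, both modest, once 3-nitrophenyl stands on the carbonyl carbon (a 2.4-fold lower number from compound 3 to compound 4 (0.39 log units; beyond the scatter); a 2.2-fold lower number from compound 1 to compound 4 (0.34 log units; beyond the scatter)). The 2,6-dichlorophenyl group is not separated from it (a 1.3-fold lower number from compound 2 to compound 4 (0.10 log units; within the scatter)), so the aryl groups shown do not split into two clear classes. No evidence at hand accounts for these steps. Open, going by these compounds, is whether the steps belong to the nitro group itself: a 3-aminophenyl or 3-carboxyphenyl group on this carbonyl carbon would test that.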